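This account rests on a few compounds, and the source may have more. Where it says the series, first, only, none or still open, it means among the compounds named here.

Working notes on the series. Compound 1 `CC(Br)C(=O)Nc1ccc(C(=O)/C=C/c2ccc(Cl)cc2)cc1` is the reference point; in a functional assay on the whole organism (strain albino) for inhibition, with Rattus norvegicus as the target, read by paw edema, with stated times of 30 min and 5 h, at a dose of 100 mg/kg by the oral route (on this read-out lower numbers stand for less inhibition and higher numbers for more inhibition at the one dose given (going by the name of the read-out)), compound 1 gives 50%. Compound 2 `COc1ccc(/C=C/C(=O)c2ccc(NC(=O)C(C)Br)cc2)cc1` differs from it by methoxy in place of chloro on an aromatic carbon, and in this assay compound 2 gives 31%. Among the compounds with values here, the step of a number 19 percentage points lower from compound 1 to compound 2 (beyond the scatter) is the only measured step in the set. On the two numbers in hand compound 2 stands lowest, with compound 1 the nearest and higher by that same step.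

Compound 3 `CC(Br)C(=O)Nc1ccc(C(=O)/C=C/c2ccco2)cc1` is not yet measured in this assay. Its change from compound 2: furan-2-yl in place of 4-methoxyphenyl on a double-bonded chain carbon bound to a double-bonded chain carbon. Within the data shown here, no measured step covers the exchange of one ring for another at this chain carbon; the single step in hand, a number 19 percentage points lower from compound 1 to compound 2 (beyond the scatter), concerns a substituent on the 4-methoxyphenyl group that now leaves, so it does not bear on this change. Among the measured compounds shown here, with no relevant step, the expectation for compound 3 in this assay is kept near compound 2 with a wide range. Compound 3 is estimated at 40%, between 15% and 65%. The expected step of a number 9 percentage points higher from compound 2 to compound 3 (within the scatter) thus lies within the scatter.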

Compound 3, a percentage reported as inhibition, in the whole organism at one dose (the size of the read-out at that dose, not a potency): 34%
For compound 3 the middle estimate is 6 percentage points above the measured one, and the stated range covers the measured number.
By their numbers in this assay, from the lowest: compounds 2 and 3 (each within the scatter of the next); then compound 1.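

At the double-bonded chain carbon bound to a double-bonded chain carbon, the ring itself can now be exchanged: in this assay, furan-2-yl in place of 4-methoxyphenyl gives a number 3 percentage points higher from compound 2 to compound 3 (within the scatter), so these two groups cannot be told apart here, even though the ring size and heavy-atom count differ. Furan-2-yl in place of 4-chlorophenyl gives a number 16 percentage points lower from compound 1 to compound 3 (beyond the scatter), which leaves 4-chlorophenyl as the one group of the three that stands apart from the other two beyond the scatter. No information is available that would account for these numbers.

The compounds shown leave open whether the standing of 4-chlorophenyl belongs to the chloro substituent or extends to other groups at this chain carbon, such as a 4-aminophenyl, a 4-carboxyphenyl or a saturated cyclohexyl ring. They also leave open how the bromine-bearing amide chain shared by all three compounds contributes, for example whether an unbrominated chain or a longer chain would give the same order, and whether these gaps hold at doses other than the one given.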